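The source may hold more compounds than are shown below. What is called first, only, known or untested is meant among the compounds shown, and "the series" means these compounds.

Compound 1 `ClCc1ccc(Cn2cnc3c(Cl)ncnc32)cc1` is the starting point of this step, but in a functional assay on SW-620 cells (Homo sapiens) for cytotoxicity, read by sulforhodamine B assay, with a stated time of 48 h (a higher number here means a weaker inhibitor of growth, a lower number a stronger inhibitor of growth), compound 1 gives "not determined" (no result reported), so there is no number that places it among the others. Two neighbours in the series do carry measurements: compound 2 `ClCc1cccc(Cn2cnc3c(Cl)nc(Cl)nc32)c1` gives 3460 nM in this assay, and compound 3 `Nc1nc(Cl)c2ncn(Cc3ccccc3CCl)c2n1` gives 11800 nM. Going by the values given here, no step between compounds that differ in one place is on record, so these two values can only be read side by side, not as a measured change. The step from compound 1 to compound 4 `Nc1nc(Cl)c2ncn(Cc3ccc(CCl)cc3)c2n1` is amino in place of hydrogen on an aromatic carbon. With no number for compound 1, the direction and size of this step cannot be measured; judging from the range that compound 2 and compound 3 span, the expectation in this assay is a weak inhibitor of growth, and no step beyond the scatter is expected in either direction. Compound 4 is expected to give about 8000 nM, in the range 2500 nM to 25000 nM.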

Compound 4, concentration for total growth inhibition: 13800 nM
Beside the measured number, compound 4's estimate is 1.7-fold (0.24 log units) below it; measured number inside the range.
By their numbers in this assay, from the lowest: compound 2; then compounds 3 and 4 (each within the scatter of the next).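

Going by these compounds alone, with compound 1 at "not determined" (no result reported) in this assay, no step from compound 1 to compound 4 can be read. Going by these compounds, whether amino in place of hydrogen on the shared core shifts growth inhibition, and in which direction, stays open. No measured evidence bears on this result.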